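The compounds below may be only part of what the source reports. "The series", "measured", "known", "first", "only" and "open" are said of these compounds alone.

Measured in a functional assay on UACC-62 cells (Homo sapiens); a higher number here means a weaker inhibitor of growth, a lower number a stronger inhibitor of growth:
- Compound 1 `O=S(=O)(/C=C/c1ccc(Br)cc1)Cc1ccc(Nc2ncnc3ccc(Br)cc23)cc1` gives > 100000 nM (a limit, not a number)
- Compound 2 `O=S(=O)(/C=C/c1ccc(Cl)cc1)Cc1ccc(Nc2ncnc3ccc(Br)cc23)cc1` gives 15000 nM

Among the compounds with values here, compound 2 holds the only actual number in this assay. For compound 1 there is only (the limit of > 100000 nM in this assay, at which 1 of the 2 values shown sits). Compound 3 `O=S(=O)(/C=C/c1ccc(Cl)cc1Cl)Cc1ccc(Nc2ncnc3ccc(Br)cc23)cc1` differs from compound 2 by chloro in place of hydrogen on an aromatic carbon, turning 4-chlorophenyl into 2,4-dichlorophenyl. Within the data shown here, one measured step bears on this, and only loosely: an at least 6.6-fold lower number from compound 1 to compound 2 (0.82 log units; beyond the scatter). That was a swap of one halogen for another, not an addition, and it gives no direction for the new chloro. No step beyond the scatter is therefore expected in this assay, though the uncertainty is wide. The expected change is no change at the digits printed from compound 2 to compound 3 (within the scatter). For compound 3 the estimated value is 15000 nM, expected to fall from 5000 nM to 50000 nM.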

Compound 3, concentration for 50% growth inhibition: 2000 nM
Compound 3: middle estimate off by 7.5-fold (0.88 log units), on the high side, and the stated range ends above it.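

In this assay, placing chloro on the aromatic carbon ortho to a large group and meta to a chloro group, which turns 4-chlorophenyl into 2,4-dichlorophenyl, gives a 7.5-fold lower number from compound 2 to compound 3 (0.88 log units; beyond the scatter) and so shows that this position responds to an added group, which a halogen swap alone could not show. Set against 4-bromophenyl, 2,4-dichlorophenyl gives an at least 50-fold lower number from compound 1 to compound 3 (1.69 log units; beyond the scatter) in this comparison. The value of compound 1 is a limit, not a number: the limit of > 100000 nM in this assay, at which 1 of the 3 values shown sits.

As far as these compounds go, whether fluoro, methyl or methoxy at this position would match chloro stays open. So does the effect of this chloro without the 4-chloro group.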